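Methyl on the Distal Ring Across Two Cores

The source may report more compounds than this note shows. Statements on the series, on what has been measured and on what is new or still open speak of the compounds shown alone.

Measured in a functional assay on BGC-823 cells (Homo sapiens) for cytotoxicity, read by CCK-8 assay, with a stated time of 24 h; a higher number here means a weaker inhibitor, a lower number a stronger inhibitor:
Compound 1, `C/C(=C\c1cc(-c2ccccc2)cs1)C(N)=O`, gives only a limit, > 50000 nM.
Compound 2, `C/C(=C\c1cc(-c2ccc(C)cc2)cs1)C(N)=O`, gives only a limit, > 50000 nM.
Compound 3, `C/C(=C\c1cccc(-c2ccccc2)c1)C(N)=O`, gives only a limit, > 50000 nM.

Going by the values given here, all three measured compounds sit at the limit of > 50000 nM in this assay, at which 3 of the 3 values shown sit, so the series so far has no number at all, only limits. Among the compounds with values here, the one step that can be set up between measured compounds is a step that the two limits leave unreadable from compound 1 to compound 2, the change being (methyl in place of hydrogen on an aromatic carbon). Both ends of that step are limits, so its size cannot be read.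

Compound 4, `C/C(=C\c1cccc(-c2ccc(C)cc2)c1)C(N)=O`, is the open compound. It stands to compound 3 as compound 2 stands to compound 1: the change is methyl in place of hydrogen on an aromatic carbon, the same change in the same place. How the core of compound 3 differs from the core of compound 1 is not broken down here.

What is expected for the step to compound 4 rests only on the limit of compound 3, > 50000 nM, and on the unreadable step between compound 1 and compound 2: a methyl entering in this place did not turn the limit of compound 2 into a number, and nothing shown suggests the same change would do so on the core of compound 3. The expected step is therefore a step that the limit leaves unreadable from compound 3 to compound 4. The estimate for compound 4 in this assay is 70000 nM, between 30000 nM and 200000 nM, with the most likely outcome being another limit rather than a number.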

Compound 4, half-maximal inhibitory concentration: > 50000 nM
Compound 4: only a limit was reported (the forecaster's own chance of this, stated with the estimate: 85%); the middle value is on the limit's open side.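

Compound 4 gives > 50000 nM in this assay, which is a limit and not a number. No new step can be read: the change from compound 3 to compound 4 has limits at both ends, and the series stays at limits throughout: the limit of > 50000 nM in this assay, at which 4 of the 4 values shown sit.

The compounds shown leave open what size the methyl step has on either core, and whether any compound on these cores gives a number in this assay.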